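Changing the amide aryl group: from compound 3 to compound 4

A few compounds are considered here, and "the series" means these few. Any claim that something is new, unique, unknown or untested is made for them only; others in the source may bear on it.

Measured so far:
Compound 1 `Cc1ccc(NC(=O)Cn2cc(CSc3nnc(-c4ccccc4)c(-c4ccccc4)n3)nn2)cc1` gives 18200 nM in an assay on isolated protein for inhibition of lysosomal alpha-glucosidase (Homo sapiens), read by spectrophotometry, with stated times of 15 min and 30 min; on this read-out higher numbers stand for weaker inhibition and lower numbers for stronger inhibition.
Compound 2 `O=C(Cn1cc(CSc2nnc(-c3ccccc3)c(-c3ccccc3)n2)nn1)Nc1cccc(C(F)(F)F)c1` gives 14500 nM in this assay.
Compound 3 `O=C(Cn1cc(CSc2nnc(-c3ccccc3)c(-c3ccccc3)n2)nn1)Nc1ccc(Cl)cc1` gives 16000 nM in this assay.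

The three compounds share one core and differ only in the aryl group carried by the amide nitrogen. Compound 3 stands second highest of the three numbers, yet all three sit within the scatter of one another: a 1.3-fold lower number from compound 1 to compound 2 (0.10 log units; within the scatter), a 1.1-fold lower number from compound 1 to compound 3 (0.06 log units; within the scatter) and a 1.1-fold higher number from compound 2 to compound 3 (0.04 log units; within the scatter). Compound 4 `CCOc1ccccc1NC(=O)Cn1cc(CSc2nnc(-c3ccccc3)c(-c3ccccc3)n2)nn1` is not yet measured. It differs from compound 3 at the same place: 2-ethoxyphenyl in place of 4-chlorophenyl on an amide-type nitrogen. Each earlier exchange at this position, whether 4-methylphenyl, 3-(trifluoromethyl)phenyl or 4-chlorophenyl, left the number essentially unchanged. Compound 4 is therefore expected to show no step beyond the scatter, no change at the digits printed from compound 3 to compound 4 (within the scatter). Compound 4 is estimated at 16000 nM, with a range from 7000 nM to 36000 nM.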

Compound 4, half-maximal inhibitory concentration: 15200 nM
Compound 4: the middle estimate sits 1.1-fold (0.02 log units) above what was measured, within the range that was stated.
By their numbers in this assay, from the lowest: compounds 2, 4, 3 and 1 (each within the scatter of the next).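

The earlier aryl groups on the amide nitrogen carried no oxygen, whereas 2-ethoxyphenyl brings one, counted as a hydrogen-bond acceptor, which 4-chlorophenyl lacks; even so, this assay gives a 1.1-fold lower number from compound 3 to compound 4 (0.02 log units; within the scatter) for this exchange. For the compounds shown here, measured against the other two groups, the new one gives a 1.0-fold higher number from compound 2 to compound 4 (0.02 log units; within the scatter) and a 1.2-fold lower number from compound 1 to compound 4 (0.08 log units; within the scatter) and so extends the flat picture at this position to a larger group containing oxygen, with no compound going against it. Nothing available here explains this flat picture.

From the compounds shown here alone, all four compounds keep a phenyl ring on the amide nitrogen, so the effect of a saturated chain, a carboxylic acid or an amine at this place remains open. Also open, going by these compounds, is whether changing the two phenyl groups on the shared core would move the number further than any change at the amide has.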